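This account rests on a few compounds, and the source may have more. Where it says the series, first, only, none or still open, it means among the compounds named here.

Measured in a functional assay on HeLa cells (Homo sapiens) for inhibition, read by CCK-8 assay, with a stated time of 48 h (on this read-out lower numbers stand for stronger inhibition and higher numbers for weaker inhibition), on one shared core:

- Compound 1 `COc1cc(-c2ccnc3cc(-c4ccc(C)c(C)c4)nn23)cc(OC)c1OC` gives 241 nM
- Compound 2 `COc1cc(-c2ccnc3cc(-c4ccc5c(ccn5C)c4)nn23)cc(OC)c1OC` gives 19 nM
- Compound 3 `COc1cc(-c2ccnc3cc(-c4ccc(N(C)C)cc4)nn23)cc(OC)c1OC` gives 378 nM

Compound 3 sits level with compound 1, since the data show a 1.6-fold higher number from compound 1 to compound 3 (0.20 log units; within the scatter) and that gap means little. Compound 2 stands well apart, with a 20-fold higher number from compound 2 to compound 3 (1.30 log units; beyond the scatter) as the measure of that distance.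

The next compound is compound 4 `C=Cc1ccc(-c2cc3nccc(-c4cc(OC)c(OC)c(OC)c4)n3n2)cc1`, which keeps the core and has vinyl in place of dimethylamino on an aromatic carbon, para to a large group (vinyl in place of dimethylamino on an aromatic carbon). In other words, 4-(dimethylamino)phenyl becomes 4-vinylphenyl.

Among the measured compounds shown here, no measured compound carries vinyl, so the guidance is indirect. For the measured compounds named here, the closest precedent is the exchange between two substituted phenyl groups, which gave a 1.6-fold higher number from compound 1 to compound 3 (0.20 log units; within the scatter) and so no real change. The one large drop, a 13-fold lower number from compound 1 to compound 2 (1.10 log units; beyond the scatter), came with 1-methyl-1H-indol-5-yl, a group that compound 4 does not contain. Compound 4 stays a substituted phenyl, so it is expected to resemble compound 3 and compound 1 rather than compound 2. The estimate in this assay is a 1.5-fold lower number from compound 3 to compound 4 (0.18 log units; within the scatter) and no step beyond the scatter is expected. Compound 4 is expected at 250 nM and estimated to fall between 70 nM and 800 nM in most repeat measurements.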

Compound 4, half-maximal inhibitory concentration: 882 nM
The estimate for compound 4 lay 3.5-fold (0.55 log units) below the measured number; measured number above the stated range.
By their numbers in this assay, from the lowest: compound 2; then compounds 1 and 3 (each within the scatter of the next); then compound 4.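

In this assay, substituted phenyl groups at this position are not all interchangeable: the swap between the groups of compound 1 and compound 3 stayed within the scatter, but vinyl in place of dimethylamino gives a 2.3-fold higher number from compound 3 to compound 4 (0.37 log units; beyond the scatter), a modest step beyond it. The 4-vinylphenyl group also separates from 3,4-dimethylphenyl, with a 3.7-fold higher number from compound 1 to compound 4 (0.56 log units; beyond the scatter), so compound 4 has the highest number of the four and the two earlier phenyl compounds both lie clearly below it. The distance to the 1-methyl-1H-indol-5-yl group widens to a 46-fold higher number from compound 2 to compound 4 (1.67 log units; beyond the scatter), so among these four compounds, that group stays well ahead of all three substituted phenyl groups.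

No measurement here gives a reason for these differences. The compounds shown leave open how ethyl, the saturated two-carbon counterpart of vinyl, would read at this same place, and whether a primary amine or a carboxylic acid there would sit nearer compound 3 or compound 4.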